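Adding a Methyl Group to Compound 2

This account rests on a few compounds, and the source may have more. Where it says the series, first, only, none or still open, it means among the compounds named here.

Compound 1 `Cc1ccc(Cc2ncn3c(O)ncnc23)cc1`: > 833000 nM
Compound 2 `Sc1ncnc2c(Cc3ccccc3)ncn12`: 35100 nM

In a functional assay on CCRF-CEM cells (Homo sapiens) for cytotoxicity (on this read-out lower numbers stand for higher toxicity in this test and higher numbers for lower toxicity in this test), compound 1 gives only a limit, > 833000 nM. Among the values shown, compound 2 gives the single real number, 35100 nM. The value of compound 1 is a limit (the limit of > 833000 nM in this assay, at which 1 of the 2 values shown sits). Compound 3 `Cc1ccc(Cc2ncn3c(S)ncnc23)cc1` differs from compound 2 by methyl in place of hydrogen on an aromatic carbon. Within the data shown here, no measured pair shows what this change does here, so the step from compound 2 to compound 3 is expected to stay within the usual scatter, with no clear direction. Compound 3 is therefore estimated at 30000 nM, between 8000 nM and 120000 nM, which means an expected step of a 1.2-fold lower number from compound 2 to compound 3 (0.07 log units; within the scatter).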

Compound 3, half-maximal cytotoxic concentration: 32800 nM
Compound 3: the middle estimate sits 1.1-fold (0.04 log units) below what was measured; the range from low to high includes it.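

In this assay, methyl in place of hydrogen on the six-membered aromatic ring of carbon only, para to a large group, stays within the scatter: a 1.1-fold lower number from compound 2 to compound 3 (0.03 log units; within the scatter). Sulfanyl in place of hydroxy on an aromatic carbon is a far larger step: an at least 25-fold lower number from compound 1 to compound 3 (1.40 log units; beyond the scatter). The value of compound 1 is only a limit: the limit of > 833000 nM in this assay, at which 1 of the 3 values shown sits.

On these data alone, whether a longer chain or an amine at the methyl's place would also stay within the scatter remains open. So does whether an amine in place of the sulfanyl would keep the lower number.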